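The source may hold more compounds than are shown below. What is called first, only, known or untested is meant among the compounds shown, and "the series" means these compounds.

Compound 1, with the structure `CC1(C)N=C(N)N=C(N)N1c1ccc(OCc2cccc(Cl)c2S(=O)(=O)F)c(Cl)c1`, is the weaker of the two measured compounds in an assay on isolated protein for inhibition of Dihydrofolate reductase (Mus musculus); on this read-out lower numbers stand for lower potency and higher numbers for higher potency (the scale is a negative logarithm); in this assay compound 1 gives 7.42. Compound 2, with the structure `CC1(C)N=C(N)N=C(N)N1c1ccc(CCc2ccc(S(=O)(=O)F)cc2Cl)c(Cl)c1`, gives 8.33 in this assay, a number that lies beyond the scatter above that of compound 1. Among the measured compounds shown here, no single-point step between these two measured compounds is available, as they differ in more than one place, so their two values are simply set side by side.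

Compound 3, with the structure `CC1(C)N=C(N)N=C(N)N1c1ccc(OCc2ccccc2S(=O)(=O)F)c(Cl)c1`, has not yet been measured in this assay. It differs from compound 1 in one place: hydrogen in place of chloro on an aromatic carbon.

For the measured compounds named here, with no measured step of this kind to lean on, the expectation for compound 3 rests on the number of compound 1 alone, and a small downward step from compound 1 to compound 3 of about a number 0.22 log units lower from compound 1 to compound 3 (within the scatter) in this assay is expected, not clearly beyond the scatter. On that basis compound 3 is estimated to give 7.2 in this assay, with a range from 6.6 to 7.8.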

Compound 3, logarithm of the reciprocal of the active concentration, log(1/C): 7.43
Compound 3: the middle estimate sits 0.23 log units below what was measured; low and high end bracket the measured number.
By their numbers in this assay, from the lowest: compounds 1 and 3 (each within the scatter of the next); then compound 2.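

In this assay, hydrogen in place of chloro on this aromatic carbon, ortho to a fluorosulfonyl group and meta to a large group, gives a number 0.01 log units higher from compound 1 to compound 3 (within the scatter). Among the compounds shown here, this is the first reading of this position, and on this read-out chloro and hydrogen there cannot be told apart, so the loss of this one chlorine atom leaves no measurable mark on the number. Nothing at hand offers an explanation for this result.

What a methyl, a methoxy group, an amine or a carboxylic acid would give on this same carbon stays open, as the compounds shown cover only chloro and hydrogen there. Also open, from the compounds shown here alone, is whether hydrogen in place of chloro would read the same way on a compound with a different link to the core, as this single step comes from one pair only.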